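Sulfonamide series: variation of the anilide ring

The source may hold more compounds than are shown below. What is called first, only, known or untested is meant among the compounds shown, and "the series" means these compounds.

Measured so far:
Compound 1 `O=C1NCCN1c1ccc(S(=O)(=O)Nc2cccc(Br)c2)cc1` — 170 nM
Compound 2 `COc1cccc(NS(=O)(=O)c2ccc(N3CCNC3=O)cc2)c1` — 200 nM

In a functional assay on HT-1080 cells (Homo sapiens) for antiproliferative activity, read by sulforhodamine B assay, with a stated time of 48 h (a higher number here means a weaker inhibitor, a lower number a stronger inhibitor), compound 1 gives 170 nM and compound 2 gives 200 nM. Compound 2 holds the higher of the two numbers recorded, with compound 1 its nearest neighbour; the step of a 1.2-fold higher number from compound 1 to compound 2 (0.07 log units; within the scatter) stays within the scatter, so the two compounds cannot be ordered on these data.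

Compound 3 `Cc1cc(C)cc(NS(=O)(=O)c2ccc(N3CCNC3=O)cc2)c1` has not yet been measured in this assay. It differs from compound 2 in one place: 3,5-dimethylphenyl in place of 3-methoxyphenyl on a sulfonamide nitrogen.

Among the measured compounds shown here, no measured step touches a 3,5-dimethylphenyl group, so the only guidance is indirect. For the measured compounds named here, the single available step, a 1.2-fold higher number from compound 1 to compound 2 (0.07 log units; within the scatter), exchanges bromo for methoxy on an aromatic carbon and produces no movement beyond the scatter, which suggests the shared core tolerates variation at this ring without a marked shift in the number. On that basis a step within the scatter is expected for compound 3, in either direction.

Compound 3 is therefore estimated at 200 nM, with a range of 90 nM to 450 nM. The expected step is no change at the digits printed from compound 2 to compound 3 (within the scatter).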

Compound 3, half-maximal inhibitory concentration: 150 nM
Estimate against measurement, compound 3: 1.3-fold (0.12 log units) above; the measured number falls inside the stated range.
By their numbers in this assay, from the lowest: compounds 3, 1 and 2 (each within the scatter of the next).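

In this assay, 3,5-dimethylphenyl in place of 3-methoxyphenyl on the sulfonamide nitrogen gives a 1.3-fold lower number from compound 2 to compound 3 (0.12 log units; within the scatter), and 3,5-dimethylphenyl in place of 3-bromophenyl at the same nitrogen gives a 1.1-fold lower number from compound 1 to compound 3 (0.05 log units; within the scatter), so compounds 1, 2 and 3 cannot be ordered on these data. The earlier pair covered only an exchange of bromo for methoxy on an aromatic carbon, whereas this result extends the comparison to a group with two methyl substituents and, unlike 3-methoxyphenyl, no oxygen and no hydrogen-bond acceptor, and the number still does not move beyond the scatter. No supporting data are available to explain this flat response.

The compounds shown leave open whether the number would hold with an amine or a carboxylic acid on the aromatic ring, with a saturated carbocycle such as cyclohexyl in place of the aromatic ring, or with a longer alkyl chain on the sulfonamide nitrogen. They also leave open how far the shared core itself tolerates change, since all three compounds carry it unaltered.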